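The source may hold more compounds than are shown below. What is called first, only, known or untested is meant among the compounds shown, and "the series" means these compounds.

Three compounds have so far been examined in a toxicity assay on NIH3T3 cells (Mus musculus) for cytotoxicity, read by resazurin assay; on this read-out higher numbers stand for an effect only at larger amounts of compound and lower numbers for an effect already at smaller amounts. Compound 1 `COC(=O)c1ccc(NCc2cncn2Cc2cccc(C#N)c2)cc1-c1ccccc1` gives > 10000 nM in this assay, which is a limit of the assay rather than a number. Compound 3 `Cc1cccc(-c2cccc(NCc3cncn3Cc3ccccc3)c2)c1` gives > 1000 nM in this assay, also a limit. Compound 2 `c1ccc(-c2ccc(Cn3cncc3CNc3ccc(-c4ccc[nH]4)c(-c4ccccc4)c3)cc2)cc1` gives > 10000 nM in this assay, again a limit and not a number. Compound 2 therefore stands where most of the shown values sit: at the limit of > 10000 nM in this assay, at which 2 of the 3 values shown sit, while the remaining value sits at the limit of > 1000 nM in this assay, at which 1 of the 3 values shown sits. Among the measured compounds shown here, no two of the three compounds differ in a single place, so no measured step can be drawn between them.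

Compound 4 `c1ccc(-c2ccc(Cn3cncc3CNc3ccc(-c4cc5ccccc5o4)c(-c4ccccc4)c3)cc2)cc1` has not yet been measured in this assay. It departs from compound 2 by 1-benzofuran-2-yl in place of 1H-pyrrol-2-yl on an aromatic carbon. For the measured compounds named here, with no measured step to lean on, the expectation for compound 4 rests on compound 2 alone. Since compound 2 sits at the limit > 10000 nM, the change is expected to bring no shift beyond the scatter, a step that the limit leaves unreadable from compound 2 to compound 4. Compound 4 is accordingly estimated to give 20000 nM in this assay, within a range of 8000 nM to 60000 nM, and it is expected that the assay will again report only a limit for compound 4.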

Compound 4, half-maximal effective concentration: > 10000 nM
Compound 4 was reported as a limit; the forecaster's own chance of this, stated with the estimate: 80%; the middle value is on the limit's open side.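

In this assay compound 4 gives > 10000 nM, which is a limit of the assay and not a number. Compound 2 likewise gives only a limit, so no step can be read between compound 2 and compound 4. The compounds shown leave open whether 1-benzofuran-2-yl in place of 1H-pyrrol-2-yl changes the amount at which an effect appears in this assay.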